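The source may hold more compounds than are shown below. What is called first, only, known or untested is meant among the compounds shown, and "the series" means these compounds.

Measured compounds in a functional assay on G-361 cells (Homo sapiens) for antiproliferative activity, with a stated time of 72 h; on this read-out lower numbers stand for stronger inhibition and higher numbers for weaker inhibition:
compound 2 `COc1cccc(CNc2ncnc3c2ncn3[C@@H]2O[C@H](CO)[C@@H](O)[C@H]2O)c1O`: 148000 nM
compound 3 `Cc1ccc(O)c(CNc2ncnc3c2ncn3[C@@H]2O[C@H](CO)[C@@H](O)[C@H]2O)c1`: > 166000 nM
compound 1 `OC[C@H]1O[C@@H](n2cnc3c(NCc4ccccc4F)ncnc32)[C@H](O)[C@@H]1O`: "not determined" (no result reported)

Compound 3 stands at the weak end of what has been measured. Its entry in this assay is a limit of the measurement and not a number; compound 3 is recorded only as > 166000 nM, and that is the limit given by the limit of > 166000 nM in this assay, at which 1 of the 3 values shown sits. Going by the values given here, compound 2 gives 148000 nM in this assay, and the one measured step, an at least 1.1-fold higher number from compound 2 to compound 3 (0.04 log units; that floor lies within the scatter), lies within the scatter, so the two values show no ordering between them.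

Compound 4 `OC[C@H]1O[C@@H](n2cnc3c(NCc4ccc(C(F)(F)F)cc4)ncnc32)[C@H](O)[C@@H]1O` differs from compound 3 by 4-(trifluoromethyl)phenyl in place of 2-hydroxy-5-methylphenyl on a saturated chain carbon bound to a nitrogen on an aromatic ring. Among the compounds with values here, no measured step involves a 4-(trifluoromethyl)phenyl group, so the only guide is that the single change at this place, from compound 2 to compound 3, did not move the number beyond the scatter. Compound 4 is therefore expected to stay near the weak region occupied by compounds 2 and 3, with an estimated step of an at least 1.1-fold lower number from compound 3 to compound 4 (0.07 log units; that floor lies within the scatter). The value of compound 4 is estimated at 140000 nM, with a range from 40000 nM to 400000 nM, and a substantial chance that only a limit is reported.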

Compound 4, half-maximal inhibitory concentration: > 166000 nM
Compound 4 ended at the assay's limit; the forecaster's own chance of this, stated with the estimate: 50%; middle value at least 1.1-fold (0.07 log units) from the limit.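

At this place on a saturated chain carbon bound to a nitrogen on an aromatic ring, the series in this assay now includes 4-(trifluoromethyl)phenyl, a group with no hydrogen-bond donor or acceptor, whereas both earlier groups carry a hydroxy group. This change gives an at least 1.1-fold higher number from compound 2 to compound 4 (0.04 log units; that floor lies within the scatter), so the loss of that hydroxy group and the entry of trifluoromethyl yield no readable separation, and the earlier picture of little movement at this place now extends to a much more different group. The step from compound 3 to compound 4 cannot be read, because both entries are limits: the limit of > 166000 nM in this assay, at which 2 of the 4 values shown sit.

From the compounds shown here alone, it remains open whether any group at this place can bring the number clearly away from this limit. A carboxylic acid or an amine on the phenyl ring, or a longer chain in place of the single carbon, could test that.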